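A few compounds are considered here, and "the series" means these few. Any claim that something is new, unique, unknown or untested is made for them only; others in the source may bear on it.

Working notes on the series. Compound 1 `Cc1c(-c2cc(Cl)cc(Cl)c2)c(C(=O)O)nn1-c1nc(-c2cnn(C)c2)c(SC(C)C)s1` belongs to the same set; in a functional assay on BJAB cells (Homo sapiens) for antiproliferative activity, with a stated time of 4 days (a higher number here means that more compound is needed for the effect, a lower number that less compound is needed), compound 1 is reported as "not active" (no number reported), with no number given. Compound 2 `Cc1nn(-c2nc(-c3ccc(Cl)c(Cl)c3)c(SC(C)C)s2)c(C(=O)O)c1-c1cccc(Cl)c1C` in this assay gives 5100 nM, the only numerical result shown, so compound 2 stands as the single reference point here. Compound 3 `Cc1nn(-c2nc(-c3ccc(Cl)c(Cl)c3)c(SC(C)C)s2)c(C(=O)O)c1-c1cc(C#N)cc(C(F)(F)F)c1` differs from compound 2 by 3-cyano-5-(trifluoromethyl)phenyl in place of 3-chloro-2-methylphenyl on an aromatic carbon. For the measured compounds named here, no measured pair isolates this change, so the direction is open; a step no larger than the usual scatter is expected, estimated as a 1.0-fold lower number from compound 2 to compound 3 (0.01 log units; within the scatter). Compound 3 is therefore expected near 5000 nM, within 1500 nM to 16000 nM.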

Compound 3, half-maximal effective concentration: 3600 nM
Estimate against measurement, compound 3: 1.4-fold (0.14 log units) above, and the stated range covers the measured number.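

On this aromatic carbon of the five-membered ring, this assay shows a 1.4-fold lower number from compound 2 to compound 3 (0.15 log units; within the scatter) for 3-cyano-5-(trifluoromethyl)phenyl in place of 3-chloro-2-methylphenyl. The position therefore carries a phenyl ring with nitrile and trifluoromethyl as well as one with chloro and methyl, and compound 2 and compound 3 cannot be told apart here. No supporting data bear on why the two read alike. On these data alone, whether an unsubstituted phenyl, a pyridine ring or an amine on this carbon would read the same stays open. Compound 1, reported without a number, offers no comparison.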